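The compounds below may be only part of what the source reports. "The series", "measured", "known", "first", "only" and "open" are said of these compounds alone.

In a functional assay on MCF7 cells (Homo sapiens) for antiproliferative activity, read by sulforhodamine B assay, with a stated time of 48 h (on this read-out higher numbers stand for weaker inhibition and lower numbers for stronger inhibition), compound 3 `O=C1NCCN1c1ccc(S(=O)(=O)Nc2ccc(F)c(F)c2)cc1` gives 620 nM, and compound 2 `CCc1ccc(NS(=O)(=O)c2ccc(N3CCNC3=O)cc2)cc1` gives 810 nM. The gap between them, a 1.3-fold lower number from compound 2 to compound 3 (0.12 log units; within the scatter), leaves the two level. Compound 1 `Cc1cccc(NS(=O)(=O)c2ccc(N3CCNC3=O)cc2)c1` gives 190 nM, the lowest number of the three and clear of both others.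

The next change leads to compound 4 `O=C1NCCN1c1ccc(S(=O)(=O)Nc2cccc(Br)c2)cc1`: 3-bromophenyl in place of 3,4-difluorophenyl on a sulfonamide nitrogen, with 3-bromophenyl in place of 3,4-difluorophenyl on a sulfonamide nitrogen. Going by the values given here, two measured steps bear on it, both modest and both leaving 3-methylphenyl: a 3.3-fold higher number from compound 1 to compound 3 (0.51 log units; beyond the scatter) and a 4.3-fold higher number from compound 1 to compound 2 (0.63 log units; beyond the scatter). Among the measured groups, 3-methylphenyl is the closest in name to 3-bromophenyl, so compound 4 is read against compound 1 at 190 nM. Among the compounds with values here, no bromine-bearing compound has been measured, so this reading is tentative and only part of that gap is carried over.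

A modest step to a lower number is expected in this assay, estimated as a 2.2-fold lower number from compound 3 to compound 4 (0.35 log units; beyond the scatter). The estimate for compound 4 is 280 nM, with an expected range of 120 nM to 650 nM.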

Compound 4, half-maximal inhibitory concentration: 100 nM
Estimate against measurement, compound 4: 2.8-fold (0.45 log units) above; measured number below the stated range.
By their numbers in this assay, from the lowest: compounds 4 and 1 (each within the scatter of the next); then compounds 3 and 2 (each within the scatter of the next).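

Notes on the sulfonamide nitrogen in this assay: 3-bromophenyl stands clear of both 3,4-difluorophenyl (a 6.2-fold lower number from compound 3 to compound 4 (0.79 log units; beyond the scatter)) and 4-ethylphenyl (an 8.1-fold lower number from compound 2 to compound 4 (0.91 log units; beyond the scatter)). Bromo in place of methyl on an aromatic carbon stays within the scatter (a 1.9-fold lower number from compound 1 to compound 4 (0.28 log units; within the scatter)), so 3-methylphenyl is no longer the only group at the low end and the two groups read as level. Across these four compounds, 3-methylphenyl and 3-bromophenyl form the low pair, and 3,4-difluorophenyl and 4-ethylphenyl form the high pair, a split claimed for these compounds only.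

No supporting data are available to account for this split. Going by these compounds, whether it extends to 3-methoxyphenyl, 3-aminophenyl, 3-carboxyphenyl or a longer chain such as 3-propylphenyl remains open.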